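The source may report more compounds than this note shows. Statements on the series, on what has been measured and on what is new or still open speak of the compounds shown alone.

Measured so far in an assay on CHO cells for positive allosteric modulation of Cystic fibrosis transmembrane conductance regulator variant F508del (Homo sapiens), using a membrane potential dye, with a stated time of 30 min, in the presence of a further agent that is not named here; a lower number here means that less compound is needed, a higher number that more compound is needed for the effect:
compound 1 `COC(=O)c1nc(-c2ccco2)c(C(F)(F)F)cc1N` gives 5310 nM
compound 2 `CNC(=O)c1nc(Br)c(C(F)(F)F)cc1N` gives 250 nM
compound 3 `CC(O)CNC(=O)c1nc(Br)c(C(F)(F)F)cc1N` gives 70 nM

Compound 3 holds the lowest number of the three; compound 2 is nearest to it, compound 1 furthest, both gaps beyond the scatter. Among the measured compounds shown here, the single measured step is a 3.6-fold lower number from compound 2 to compound 3 (0.55 log units; beyond the scatter). The change between these two compounds sits on the chain attached to the amide-type nitrogen. Compound 4 `Nc1cc(C(F)(F)F)c(Br)nc1C(=O)NC[C@@H](O)C(F)(F)F` is the next member. 2,2,2-trifluoro-1-hydroxyethyl in place of 1-hydroxyethyl on a saturated chain carbon bound to an amide-type nitrogen The measured step bears on the same chain but only shows that lengthening it helped; nothing measured speaks to fluorine on that chain. Without a closer precedent the step from compound 3 to compound 4 is expected to be a 1.1-fold higher number from compound 3 to compound 4 (0.06 log units; within the scatter), within the scatter. Compound 4 is therefore estimated at 80 nM, range 25 nM to 250 nM.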

Compound 4, half-maximal effective concentration: 9 nM
Compound 4: the middle estimate sits 8.9-fold (0.95 log units) above what was measured; measured number outside the range, below it.
By their numbers in this assay, from the lowest: compound 4; then compound 3; then compound 2; then compound 1.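

In this assay, this position on a saturated chain carbon bound to an amide-type nitrogen still has room for gain: 2,2,2-trifluoro-1-hydroxyethyl in place of 1-hydroxyethyl gives a 7.8-fold lower number from compound 3 to compound 4 (0.89 log units; beyond the scatter), a larger step than the earlier one on this chain. Measured against hydrogen at the same place, the overall change is a 28-fold lower number from compound 2 to compound 4 (1.44 log units; beyond the scatter). Nothing available accounts for the effect of the fluorines.

Open, as far as these compounds go, is whether the opposite configuration at the defined stereocentre keeps this gain. Also open, from the compounds shown here alone, is whether an amine in place of the hydroxyl, or a difluoromethyl or longer fluoroalkyl chain, matches it.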